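A few compounds are considered here, and "the series" means these few. Any claim that something is new, unique, unknown or untested is made for them only; others in the source may bear on it.

Compound 1 `Fc1ccc(N2CCN(c3nc(-n4ccc5ccccc54)c4ccccc4n3)CC2)cc1`: 50 ug/mL
Compound 2 `COc1ccc(-c2nc(N3CCNCC3)nc3ccccc23)c(OC)c1`: 50 ug/mL
Compound 3 `c1ccc2c(c1)ccn2-c1nc(N2CCCCC2)nc2ccccc12`: 50 ug/mL

All three compounds were tested in an ADME assay on Vero cells (Chlorocebus sabaeus) for antiproliferative activity, read by MTT assay; on this read-out higher numbers stand for weaker inhibition and lower numbers for stronger inhibition. In this assay, compound 2 gives 50 ug/mL, level with compound 1 and compound 3 at the digits reported, so these three show no spread on this read-out. Going by the values given here, no two of them differ in only one place, which leaves no measured step to show how a single change moves the number.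

Compound 4 `COc1cc(OC)c(-c2nc(N3CCNCC3)nc3ccccc23)c(OC)c1` has not yet been measured. It differs from compound 2 by a single change, methoxy in place of hydrogen on an aromatic carbon. Among the compounds with values here, the data hold no direct precedent for this change, so any expectation rests on the flat values alone. Structures that differ from compound 2 in more than one place still match it, as compound 1 does at 50 ug/mL and compound 3 does at 50 ug/mL. No step beyond the scatter is therefore expected in this assay, and neither direction is favoured. The expected change, no change at the digits printed from compound 2 to compound 4 (within the scatter), is correspondingly small. For compound 4 the estimated value is 50 ug/mL, with an expected range from 25 ug/mL to 100 ug/mL.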

Compound 4, half-maximal inhibitory concentration: 50 ug/mL
Compound 4: the middle estimate sits on the measured number at the digits printed; measured number inside the range.
By their numbers in this assay, from the lowest: compounds 1, 2, 3 and 4 (each within the scatter of the next).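

In this assay, the study now has its first step between two compounds that differ in one place: methoxy in place of hydrogen on an aromatic carbon gives no change at the digits printed from compound 2 to compound 4 (within the scatter) on this read-out. Going by these compounds alone, the earlier compounds offered no such pair, so this is the first direct reading at this position, on a six-membered aromatic ring of carbon only, ortho to a large group and meta to two methoxy groups, and here the added methoxy leaves the two compounds reading alike. No measurement shown explains this flat result.

The compounds shown leave open whether a different group at this same position, such as a hydroxyl, a fluorine or an amine, would also read alike with compound 2. They also leave open whether a methoxy on another carbon of this ring, or a longer chain such as ethoxy at this position, would give a step beyond the scatter.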